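Two Chlorines on a Phenylpiperazine: Growth Inhibition Expected

The source may hold more compounds than are shown below. What is called first, only, known or untested is meant among the compounds shown, and "the series" means these compounds.

Compound 1 `N#Cc1ccc(Nc2nc(Oc3ccnc4ccccc34)nc(N3CCN(c4ccccc4Cl)CC3)n2)cc1C(F)(F)F` gives 92600 nM in a functional assay on DU-145 cells (Homo sapiens) for cytotoxicity, read by sulforhodamine B assay, with a stated time of 48 h; on this read-out lower numbers stand for stronger inhibition of growth and higher numbers for weaker inhibition of growth.
Compound 2 `CC(C)N1CCN(c2nc(Nc3ccc(C#N)c(C(F)(F)F)c3)nc(Oc3ccnc4ccccc34)n2)CC1` shows only a limit, > 100000 nM.
Compound 3 `N#Cc1ccc(Nc2nc(Oc3ccnc4ccccc34)nc(N3CCN(c4ccccc4)CC3)n2)cc1C(F)(F)F` likewise shows only a limit, > 100000 nM.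

Compound 3 thus stands at the ceiling of this assay, sharing the limit of > 100000 nM in this assay, at which 2 of the 3 values shown sit, with compound 2. Compound 4 `N#Cc1ccc(Nc2nc(Oc3ccnc4ccccc34)nc(N3CCN(c4cccc(Cl)c4Cl)CC3)n2)cc1C(F)(F)F` differs from compound 3 by 2,3-dichlorophenyl in place of phenyl on an amine nitrogen in a ring. For the measured compounds named here, the only measured step that bears on this is an at least 1.0-fold higher number from compound 1 to compound 3 (0.03 log units; that floor lies within the scatter), where removing a single chloro left the number within the scatter; the change here runs the other way and adds two. A step of an at least 1.1-fold lower number from compound 3 to compound 4 (0.07 log units; that floor lies within the scatter) is therefore expected, none beyond the scatter, with a fair chance that only a limit is reported again. The estimate for compound 4 is 85000 nM, between 35000 nM and 200000 nM.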

Compound 4, concentration for 50% growth inhibition: > 100000 nM
Compound 4 gave a limit, no number; the forecaster's own chance of this, stated with the estimate: 50%; at least 1.1-fold (0.07 log units) between middle value and limit.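

Putting 2,3-dichlorophenyl on the amine nitrogen in the ring did not bring compound 4 a measurable number; it gave only a limit, so the steps from compound 2 and compound 3 cannot be read. For the compounds shown here, the one readable step, for the added chloro, is an at least 1.0-fold higher number from compound 1 to compound 4 (0.03 log units; that floor lies within the scatter). A second chloro therefore showed no gain beyond the scatter, and compound 4 joins the ceiling: the limit of > 100000 nM in this assay, at which 3 of the 4 values shown sit.

From the compounds shown here alone, whether a methoxy or a carboxylic acid on that phenyl would give a clear number remains open. So does how the three compounds at the limit truly compare with one another.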